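From compound 1 to compound 4: working notes

This account rests on a few compounds, and the source may have more. Where it says the series, first, only, none or still open, it means among the compounds named here.

compound 1 `Cc1c(C)c2c(c(C)c1N)CC(C)(C)O2` gives 7.8 mg/kg
compound 2 `Cc1c(C)c2c(c(N)c1N)CC(C)(C)O2` gives > 50 mg/kg
compound 3 `Cc1c(C)c2c(c(C)c1N)CC(C)(CSc1ccncc1)O2` gives 19.9 mg/kg

In a functional assay on the whole organism with Mus musculus as the target (a higher number here means that more compound is needed for the effect, a lower number that less compound is needed), compound 1 at 7.8 mg/kg holds the lower of the two actual numbers, and the nearest value is that of compound 3 at 19.9 mg/kg on the higher side. For compound 2 the entry > 50 mg/kg is a limit of the assay and not a number.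

Compound 4 `COC(=O)/C=C\C1(C)Cc2c(C)c(N)c(C)c(C)c2O1` is still unmeasured. Its change from compound 1 is 2-(methoxycarbonyl)ethenyl in place of methyl on a saturated ring carbon with 2-(methoxycarbonyl)ethenyl in place of methyl on a saturated ring carbon.

The closest measured evidence is a 2.6-fold higher number from compound 1 to compound 3 (0.41 log units; beyond the scatter) for (pyridin-4-yl)sulfanyl in place of hydrogen on a saturated chain carbon bound to a saturated ring carbon. Going by the values given here, this is a modest rise, and it is the only measured change at that part of the core. The other measured change, an at least 6.4-fold higher number from compound 1 to compound 2 (0.80 log units; beyond the scatter) on an aromatic carbon, lies elsewhere and bears little on compound 4. A modest rise in the number is therefore expected, of similar size to the step to compound 3, though on thin evidence. The expected step is a 2.3-fold higher number from compound 1 to compound 4 (0.36 log units; beyond the scatter) in this estimate. For compound 4 the estimated value is 18 mg/kg in this assay as a central expectation. The expected range for compound 4 runs from 7 mg/kg to 45 mg/kg on this reasoning.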

Compound 4, dose for 50% inhibition: > 100 mg/kg
Compound 4: only a limit was reported; the forecaster's own chance of this, stated with the estimate: 12%; at least 5.5-fold (0.74 log units) between middle value and limit.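

In this assay, 2-(methoxycarbonyl)ethenyl in place of methyl on the saturated ring carbon next to the ring oxygen gives an at least 12-fold higher number from compound 1 to compound 4 (1.10 log units; beyond the scatter). For compound 4 the reading is a limit of the assay and not a number: the limit of > 100 mg/kg in this assay, at which 1 of the 4 values shown sits. Until now this part of the core had shown only a modest rise, a 2.6-fold higher number from compound 1 to compound 3 (0.41 log units; beyond the scatter), with (pyridin-4-yl)sulfanyl on a saturated chain carbon bound to a saturated ring carbon, whereas the new change gives a large step and shows that the number in this assay can respond strongly to what is placed on this ring carbon.

On these data alone, how a carboxylic acid, a saturated ester chain or a plain ethyl group would read at this ring carbon stays open, and with it whether the rise goes with the methyl ester, with the double bond or simply with a longer chain. Also open, as far as these compounds go, is how far compound 4 lies past its limit, so the step has a lower bound but no measured size.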